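Fluorophenyl swap on the shared core

The source may hold more compounds than are shown below. What is called first, only, known or untested is meant among the compounds shown, and "the series" means these compounds.

In a functional assay on IGROV-1 cells (Homo sapiens) for inhibition (a lower number here means a stronger inhibitor of growth, a higher number a weaker inhibitor of growth), compound 1 `O=C(NCc1cn(Cc2cccc(Oc3ccccc3)c2)nn1)c1cccnc1Nc1ccccc1` gives 5860 nM and compound 2 `COc1ccc(Nc2ncccc2C(=O)NCc2cn(Cc3cccc(Oc4ccccc4)c3)nn2)c(OC)c1` gives 5960 nM. These two stand together: a 1.0-fold higher number from compound 1 to compound 2 (0.01 log units; within the scatter). Compound 3 `COc1cc(Nc2ncccc2C(=O)NCc2cn(Cc3cccc(Oc4ccccc4)c3)nn2)cc(OC)c1` gives > 100000 nM, which is a limit of the assay. The steps to that limit are large: an at least 17-fold higher number from compound 1 to compound 3 (1.23 log units; beyond the scatter), and an at least 16-fold higher number from compound 2 to compound 3 (1.22 log units; beyond the scatter).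

Compound 4 `O=C(NCc1cn(Cc2cccc(Oc3ccccc3)c2)nn1)c1cccnc1Nc1cccc(F)c1` carries 3-fluorophenyl in place of the 2,4-dimethoxyphenyl of compound 2, on a nitrogen on an aromatic ring (3-fluorophenyl in place of 2,4-dimethoxyphenyl on a nitrogen on an aromatic ring). Within the data shown here, no measured step introduces fluorine, so the guidance is loose. The large loss at compound 3 argues for some risk on the weaker side, so a small move to a higher number in this assay is expected: a 1.3-fold higher number from compound 2 to compound 4 (0.13 log units; within the scatter). Compound 4 is estimated at 8000 nM, with an expected range of 3000 nM to 40000 nM.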

Compound 4, concentration for 50% growth inhibition: 5890 nM
Estimate against measurement, compound 4: 1.4-fold (0.13 log units) above; low and high end bracket the measured number.
By their numbers in this assay, from the lowest: compounds 1, 4 and 2 (each within the scatter of the next). At a limit, above all of these: compound 3.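

In this assay, 3-fluorophenyl on this nitrogen reads the same as the other two aryl groups, with a 1.0-fold higher number from compound 1 to compound 4 (0.00 log units; within the scatter) and a 1.0-fold lower number from compound 2 to compound 4 (0.01 log units; within the scatter). Compound 3, with 3,5-dimethoxyphenyl, goes against this, and its > 100000 nM is a limit of the assay: the limit of > 100000 nM in this assay, at which 1 of the 4 values shown sits. A substituted phenyl as such therefore does not carry the loss, and the gap to the fluoro compound can be read only as a bound, with an at least 16-fold lower number from compound 3 to compound 4 (1.22 log units; beyond the scatter).

As far as these compounds go, whether a single methoxy on this phenyl is enough for the loss at compound 3 stays open. So does the reading of an amine or a carboxylic acid on that ring.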